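The source may report more compounds than this note shows. Statements on the series, on what has been measured and on what is new or still open speak of the compounds shown alone.

Compound 3, drawn as `C=CC1=C(C(=O)NCc2ccccc2F)C(c2ccc(F)cc2)OC1`, is the weaker of the two compounds for which a number exists. In a functional assay on QGY7701 cells (Homo sapiens) for cytotoxicity, read by MTT assay, with a stated time of 24 h (a lower number here means a stronger inhibitor, a higher number a weaker inhibitor), compound 3 gives 51400 nM. Its nearest neighbour is compound 2, drawn as `C=CC1=C(C(=O)NCc2ccc(Cl)cc2)C(c2ccc(F)cc2)OC1`, which in this assay gives 36900 nM; the gap between the two is a 1.4-fold higher number from compound 2 to compound 3 (0.14 log units; within the scatter). Compound 1, drawn as `C=CC1=C(C(=O)NCCC)C(c2ccc(F)cc2)OC1`, gives only a limit in this assay, > 100000 nM, so its true number is not known.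

Compound 4, drawn as `C=CC1=C(C(=O)NCC(C)C)C(c2ccc(F)cc2)OC1`, differs from compound 3 in one place: isopropyl in place of 2-fluorophenyl on a saturated chain carbon bound to an amide-type nitrogen. The step that bears most closely on this change is the one running the other way, from an ethyl chain to the 2-fluorophenyl ring, which read an at least 1.9-fold lower number from compound 1 to compound 3 (0.28 log units; that floor lies within the scatter); the sister step to a 4-chlorophenyl ring read an at least 2.7-fold lower number from compound 1 to compound 2 (0.43 log units; beyond the scatter). Both put a ring on that carbon and both lowered the number, the first only to a floor within the scatter, the second more clearly. Swapping the ring back for an isopropyl chain is therefore expected to move the number upward, and a limit like that of compound 1 the limit of > 100000 nM in this assay, at which 1 of the 3 values shown sits, is a real possibility.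

For compound 4 the estimated step is a 1.8-fold higher number from compound 3 to compound 4 (0.24 log units; within the scatter), giving an expected value of 90000 nM, in a range from 40000 nM to 200000 nM.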

Compound 4, half-maximal inhibitory concentration: > 100000 nM
Compound 4 gave a limit, no number; the forecaster's own chance of this, stated with the estimate: 50%; middle value at least 1.1-fold (0.04 log units) from the limit.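

In this assay compound 4 gives only a limit, not a number, and it now shares that limit with compound 1, so neither compound with an open chain rather than a ring on the saturated chain carbon bound to an amide-type nitrogen gives a number: the limit of > 100000 nM in this assay, at which 2 of the 4 values shown sit.

Replacing either ring with isopropyl raises the number, with the change from the 4-chlorophenyl compound reading an at least 2.7-fold higher number from compound 2 to compound 4 (0.43 log units; beyond the scatter) and the change from the 2-fluorophenyl compound reading an at least 1.9-fold higher number from compound 3 to compound 4 (0.28 log units; that floor lies within the scatter). Compound 4 carries one more methyl on its chain than compound 1, yet this branching brings no number into view, and the step between these two compounds cannot be read.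

On these data alone, how far the true values of compound 1 and compound 4 lie past the limit remains unknown, so the full size of the change from ring to chain stays open. The compounds shown also leave open whether an unsubstituted phenyl ring, a longer chain, an amine or a carboxylic acid at this position would give a measurable number in this assay.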